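Ring size of the aminomethyl group: compound 3 to compound 4

A few compounds are considered here, and "the series" means these few. Any claim that something is new, unique, unknown or untested is made for them only; others in the source may bear on it.

Values in an assay on COS-7 cells for inhibition of patatin-like phospholipase domain-containing protein 2 (Mus musculus); a lower number here means a stronger inhibitor, a higher number a weaker inhibitor:
compound 1, `CCOC(=O)c1cccc(-c2ccc(O)cc2)c1`: 100000 nM
compound 2, `CCOC(=O)c1cccc(-c2ccc(N(C)C)cc2)c1`: 40000 nM
compound 3, `CCOC(=O)c1cccc(-c2ccc(CN3CCCC3)cc2)c1`: > 200000 nM, which is a limit of the assay and not a number.

For the measured compounds named here, compound 3 therefore stands only as a limit; it is the one of the three values that sits at the limit of > 200000 nM in this assay, at which 1 of the 3 values shown sits. Both steps that end in it point the same way: an at least 2.0-fold higher number from compound 1 to compound 3 (0.30 log units; that floor lies within the scatter) and an at least 5.0-fold higher number from compound 2 to compound 3 (0.69 log units; beyond the scatter), the second beyond the scatter, the first with a floor that lies within it. Compound 4, `CCOC(=O)c1cccc(-c2ccc(CN3CCCCC3)cc2)c1`, differs from compound 3 by piperidin-1-yl in place of pyrrolidin-1-yl on a saturated chain carbon bound to an aromatic carbon. Going by the values given here, no measured step compares two ring sizes on that saturated chain carbon, so the only steps that bear on the change are the two ending in compound 3, which already reach the limit. No step beyond the scatter in this assay is expected from that change. Compound 4 is expected at 300000 nM, with a range from 150000 nM to 1000000 nM, most probably reported again only as a limit. The expected step is a step that the limit leaves unreadable from compound 3 to compound 4.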

Compound 4, half-maximal inhibitory concentration: 75000 nM
Beside the measured number, compound 4's estimate is 4.0-fold (0.60 log units) above it; measured number below the stated range.
By their numbers in this assay, from the lowest: compounds 2, 4 and 1 (each within the scatter of the next, the first and the last beyond it). At a limit, above all of these: compound 3.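

In this assay, for the compounds shown here, piperidin-1-yl in place of pyrrolidin-1-yl on a saturated chain carbon bound to an aromatic carbon gives an at least 2.6-fold lower number from compound 3 to compound 4 (0.42 log units; beyond the scatter), the first measured comparison of two ring sizes at this place. Compound 3 has a limit of the assay and not a number, so that step gives only a floor: the limit of > 200000 nM in this assay, at which 1 of the 4 values shown sits. The (piperidin-1-yl)methyl group also falls within the scatter of both earlier groups, with a 1.9-fold higher number from compound 2 to compound 4 (0.27 log units; within the scatter) and a 1.3-fold lower number from compound 1 to compound 4 (0.12 log units; within the scatter), so a (piperidin-1-yl)methyl group at this place cannot be separated from dimethylamino or hydroxy in this assay.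

From the compounds shown here alone, whether a larger ring such as azepan-1-yl or a ring with an added oxygen such as morpholin-4-yl follows compound 4 or compound 3 stays open. Going by these compounds, the effect of a carboxylic acid in place of the ethyl ester on these values also stays open.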